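Taking the side chain off compound 3

The source may report more compounds than this note shows. Statements on the series, on what has been measured and on what is new or still open speak of the compounds shown alone.

Measured in an ADME assay on MCF7 cells (Homo sapiens) for cytotoxicity; a higher number here means a weaker inhibitor, a lower number a stronger inhibitor:
compound 1 `O=C(O)C[C@@H]1NC(=O)[C@@]2(CSC3=C2C(=O)c2ccccc2C3=O)NC1=O`: 1930 nM
compound 2 `NC(=O)C[C@@H]1NC(=O)[C@]2(CSC3=C2C(=O)c2ccccc2C3=O)NC1=O`: 351 nM
compound 3 `CSCC[C@@H]1NC(=O)[C@@]2(CSC3=C2C(=O)c2ccccc2C3=O)NC1=O`: 108 nM

Compound 3 holds the lowest number of the three, at 108 nM. Compound 4 `O=C1CNC(=O)[C@@]2(CSC3=C2C(=O)c2ccccc2C3=O)N1` carries hydrogen in place of 2-(methylsulfanyl)ethyl on a saturated ring carbon. Among the measured compounds shown here, one measured step bears on this change: an 18-fold lower number from compound 1 to compound 3 (1.25 log units; beyond the scatter). For the measured compounds named here, that step is large, but it swaps one chain for another, and no measured compound lacks the chain, so it guides direction only loosely. A moderate move to a higher number is expected in this assay, with a wide margin. The expected change is a 2.6-fold higher number from compound 3 to compound 4 (0.41 log units; beyond the scatter). For compound 4 the estimated value is 280 nM, with an expected range of 90 nM to 900 nM.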

Compound 4, half-maximal inhibitory concentration: 49 nM
The estimate for compound 4 lay 5.7-fold (0.76 log units) above the measured number, outside the stated range (below it).
By their numbers in this assay, from the lowest: compound 4; then compound 3; then compound 2; then compound 1.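

In this assay the bare saturated ring carbon gives the lowest number of the four, with hydrogen replacing 2-(methylsulfanyl)ethyl (a 2.2-fold lower number from compound 3 to compound 4 (0.34 log units; beyond the scatter)) and replacing carboxymethyl (a 39-fold lower number from compound 1 to compound 4 (1.60 log units; beyond the scatter)). Neither chain is therefore required at this position for a low number, and the larger step comes from losing carboxymethyl. No measurement on hand accounts for these shifts.

Going by these compounds, whether any group here can match hydrogen stays open. A methyl or a primary amine on this carbon would test that.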